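Swapping (3,4-dichlorophenyl)amino for phenyl on a carbonyl carbon

A few compounds are considered here, and "the series" means these few. Any claim that something is new, unique, unknown or untested is made for them only; others in the source may bear on it.

Compound 1 (`COc1cc(-c2nn(-c3cccc(NC(=O)Nc4ccc(Cl)c(Cl)c4)c3)cc2-c2ccncc2)ccc1Cl`) gives 1560 nM
Compound 2 (`O=C(Nc1cccc(-n2cc(-c3ccncc3)c(-c3ccc(Cl)c(O)c3)n2)c1)Nc1ccc(Cl)c(Cl)c1`) gives 2890 nM

Both numbers come from a functional assay on HCC 2998 cells (Homo sapiens) for inhibition, read by sulforhodamine B assay, with a stated time of 48 h (a higher number here means a weaker inhibitor of growth, a lower number a stronger inhibitor of growth), and lie within the scatter of each other, so compound 1 has no clear rank against compound 2. The core of compound 1 stays in compound 3 (`COc1cc(-c2nn(-c3cccc(NC(=O)c4ccccc4)c3)cc2-c2ccncc2)ccc1Cl`), and the change is phenyl in place of (3,4-dichlorophenyl)amino on a carbonyl carbon here. Cut one bond further out, (3,4-dichlorophenyl)carbamoyl becomes benzoyl.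

Within the data shown here, no measured step touches this place. Among the measured compounds shown here, the only step available is a 1.9-fold higher number from compound 1 to compound 2 (0.27 log units; within the scatter) and it swaps hydrogen for methyl on an oxygen on an aromatic ring, so it offers no size to carry over. The new change replaces a far larger piece of the molecule than that step did. A move towards a weaker inhibitor, meaning a higher number in this assay, is therefore expected, though with wide uncertainty. The starting point is compound 1 at 1560 nM for this estimate. Compound 3 is estimated at 3500 nM with an expected range from 1200 nM to 12000 nM in this assay. That estimate means a 2.2-fold higher number from compound 1 to compound 3 (0.35 log units; beyond the scatter) as the expected step.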

Compound 3, concentration for 50% growth inhibition: 2320 nM
Estimate against measurement, compound 3: 1.5-fold (0.18 log units) above, and the stated range covers the measured number.
By their numbers in this assay, from the lowest: compounds 1, 3 and 2 (each within the scatter of the next).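

In this assay, among these compounds, this is the first reading at the carbonyl carbon, since the earlier pair differed only in a methyl on an oxygen on an aromatic ring, and the swap of (3,4-dichlorophenyl)amino for phenyl gives a 1.5-fold higher number from compound 1 to compound 3 (0.17 log units; within the scatter). The group that leaves carries both chlorine atoms and the hydrogen-bond donor, yet compound 3 cannot be told apart from compound 1 here, so neither feature is shown to be required for growth inhibition at this level in these cells. No measurement is available to explain this result.

From the compounds shown here alone, the change removes the chlorine atoms and the amino nitrogen together, so their separate contributions remain open, and a 3,4-dichlorophenyl group placed directly on the carbonyl carbon would separate the two. It is also open how this position responds to a group other than an aromatic ring, such as cyclohexyl or morpholine on the same carbonyl carbon, because the compounds shown carry only (3,4-dichlorophenyl)amino and phenyl there.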